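A few compounds are considered here, and "the series" means these few. Any claim that something is new, unique, unknown or untested is made for them only; others in the source may bear on it.

Working notes on the series.

Compound 1 `COc1cc(OC)c(-c2cc(=O)c3cc(O)ccc3o2)cc1OC` is the flavone-type member of the set. In a functional assay on MCF7 cells (Homo sapiens) for inhibition, read by MTT assay, with a stated time of 72 h (a higher number here means a weaker inhibitor, a lower number a stronger inhibitor), compound 1 returns only a limit, > 150000 nM, so no number is known for it. Among the measured compounds shown here, that leaves compound 1 sitting at the limit of > 150000 nM in this assay, at which 1 of the 3 values shown sits, with no measured step to any other member. The two chalcones give numbers: compound 2 `COc1cc(OC)c(OC)cc1/C=C/C(=O)c1ccc(Cl)c([N+](=O)[O-])c1` gives 16400 nM in this assay, and compound 3 `COc1cc(C(=O)/C=C/c2cc(OC)c(OC)cc2OC)ccc1O` gives 95500 nM in this assay. Those two values are all that can be said of that pair, since no single-point change links them to compound 1 or to each other.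

The unmeasured compound 4 `COc1cc(OC)c(-c2cc(=O)c3cc(Cl)ccc3o2)cc1OC` differs from compound 1 by chloro in place of hydroxy on an aromatic carbon, the chloro sitting meta to a fused ring and para to a fused ring on the shared core. With compound 1 known only as a limit, the size of the step in this assay cannot be anchored; the expectation is for no step beyond the usual scatter, and the step from compound 1 to compound 4 is estimated as a number no higher from compound 1 to compound 4 (the limit leaves the size open). Compound 4 is therefore expected to give 150000 nM in this assay, within 50000 nM to 450000 nM, with a fair chance that it again returns only a limit.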

Compound 4, half-maximal inhibitory concentration: > 150000 nM
Compound 4 was reported as a limit (the forecaster's own chance of this, stated with the estimate: 55%); the middle value sits exactly at the limit.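

In this assay compound 4 gives > 150000 nM, a limit of the assay and not a number. Compound 1 is also known only as a limit, so no step can be read between compound 1 and compound 4, which stand together: the limit of > 150000 nM in this assay, at which 2 of the 4 values shown sit.

The compounds shown leave open what chloro in place of hydroxy on an aromatic carbon does to the value in this assay.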